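The source may report more compounds than this note shows. Statements on the series, on what has been measured and on what is new or still open speak of the compounds shown alone.

Of the compounds shown here, three from this series have been measured in an assay for inhibition of Polyunsaturated fatty acid 5-lipoxygenase (Homo sapiens), read by spectrophotometry, tested at 10 uM, in the presence of a further agent that is not named here; on this read-out lower numbers stand for less inhibition and higher numbers for more inhibition at the one concentration tested (going by the name of the read-out). Compound 1 `Cc1ccc(/C=C/C(=O)c2sc(NC(=O)c3ccc(F)cc3)nc2C)cc1` gives 91.5%, compound 2 `Cc1nc(NC(=O)c2ccc(F)cc2)sc1C(=O)/C=C/c1ccc(N(C)C)cc1` gives 70.2%, and compound 3 `Cc1nc(NC(=O)c2ccccc2)sc1C(=O)/C=C/c1ccco1` gives 57.2%. Compound 3 therefore stands lowest of the three: compound 2 is its nearest neighbour, and compound 1 the furthest, both beyond the scatter. Among the measured compounds shown here, the one measured step between neighbours, a number 21.3 percentage points lower from compound 1 to compound 2 (beyond the scatter), concerns a change on the other end of the molecule.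

Compound 4 `Cc1nc(NC(=O)c2ccc(F)cc2)sc1C(=O)/C=C/c1ccco1` differs from compound 3 in one place: fluoro in place of hydrogen on an aromatic carbon. For the measured compounds named here, no measured pair shows this same change, so the step from compound 1 to compound 2 does not bear on it directly. Compounds 1 and 2 both carry the 4-fluorophenyl group and score higher than compound 3, but they also differ from it in the group on the double bond, so their values cannot be read as the effect of the fluoro alone. With nothing comparable to go on, a step no larger than the scatter is expected, if anything leaning upward. Compound 4 is estimated at 63%, between 45% and 80%, which means an expected step of a number 5.8 percentage points higher from compound 3 to compound 4 (within the scatter).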

Compound 4, a percentage reported as inhibition, at one concentration (the size of the read-out at that concentration, not a potency): 65.3%
Estimate against measurement, compound 4: 2.3 percentage points below, and the stated range covers the measured number.
By their numbers in this assay, from the lowest: compounds 3, 4 and 2 (each within the scatter of the next, the first and the last beyond it); then compound 1.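

The fluoro, on the six-membered aromatic ring and para to a large group, gives a number 8.1 percentage points higher from compound 3 to compound 4 (within the scatter) in this assay, so with furan-2-yl on the chain this change cannot be told apart from the scatter. Among the compounds shown here, with 4-fluorophenyl held fixed, compound 4 also offers the first direct reading of the chain group: furan-2-yl in place of 4-(dimethylamino)phenyl gives a number 4.9 percentage points lower from compound 2 to compound 4 (within the scatter), whereas furan-2-yl in place of 4-methylphenyl gives a number 26.2 percentage points lower from compound 1 to compound 4 (beyond the scatter), which leaves compound 1 apart from both other fluoro compounds. Nothing available here offers a reason for any of these steps.

For the compounds shown here, whether the fluoro would count for more with 4-methylphenyl or 4-(dimethylamino)phenyl on the chain remains an open question, since the only reading of this change has furan-2-yl there. From the compounds shown here alone, it is also open how a chloro, a methoxy or an amine at the same place on the ring would compare with fluoro and hydrogen in this assay.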